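Adding a second hydroxy to compound 1: expected readout

This account rests on a few compounds, and the source may have more. Where it says the series, first, only, none or still open, it means among the compounds named here.

Measured so far:
compound 1 `COc1ccc(/C=C/C(=O)c2ccc(O)cc2)cc1Br` gives 6.6%
compound 2 `COc1ccc(/C=C/C(=O)c2ccc(F)cc2)cc1Br` gives 20.1%
compound 3 `O=C(/C=C/c1ccc(F)cc1)c1ccc(O)cc1` gives 18%

In an assay on isolated protein for inhibition of DNA topoisomerase 1 (Homo sapiens), tested at 20 uM (a lower number here means a weaker effect, a higher number a stronger effect of the compound at the concentration tested), compound 1 stands lowest of the three numbers. Compound 3 lies nearest to it, with a value beyond the scatter above it, and compound 2 lies furthest, also beyond the scatter. Among the measured compounds shown here, the only single-point step among the measured compounds is a number 13.5 percentage points higher from compound 1 to compound 2 (beyond the scatter); it swaps one group for another on the same ring and says nothing about adding a group elsewhere.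

Compound 4 `COc1ccc(/C=C/C(=O)c2ccc(O)cc2O)cc1Br` differs from compound 1 by hydroxy in place of hydrogen on an aromatic carbon. The added hydroxy sits on an aromatic carbon of a six-membered aromatic ring of carbon only, ortho to a large group and meta to a hydroxy group. For the measured compounds named here, no measured step bears on this change: neither compound 2 nor compound 3 carries an added hydroxy relative to any other compound in the set. With nothing to lean on, the expectation for this assay is a step from compound 1 to compound 4 of no clear size in either direction, most likely within the scatter, and this is what a number 3.4 percentage points higher from compound 1 to compound 4 (within the scatter) expresses.

Compound 4 is therefore estimated at 10%, with a range from 2% to 25%.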

Compound 4, a percentage reported as inhibition, at one concentration (the size of the read-out at that concentration, not a potency): 8.2%
Beside the measured number, compound 4's estimate is 1.8 percentage points above it; measured number inside the range.
By their numbers in this assay, from the lowest: compounds 1, 4, 3 and 2 (each within the scatter of the next, the first and the last beyond it).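

In this assay, hydroxy in place of hydrogen on an aromatic carbon, ortho to a large group and meta to a hydroxy group, gives a number 1.6 percentage points higher from compound 1 to compound 4 (within the scatter). Among the compounds shown here, this is the first reading of an added group on this ring, and at this position the added hydroxy produces no step that can be told apart from the scatter. The earlier step, a number 13.5 percentage points higher from compound 1 to compound 2 (beyond the scatter), replaced a group already present and lies beyond the scatter, so of the two single changes from compound 1 shown here, only the fluoro exchange gives a readable difference; no measurement shown gives any reason for either outcome.

Still open, on these data alone, is whether an amine or a carboxylic acid on the same aromatic carbon, ortho to a large group, would give a step beyond the scatter in this assay or would also stay within it. Also open, as far as these compounds go, is whether the same added hydroxy on the core of compound 2, where fluoro stands in place of the first hydroxy, would give a step of similar size.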